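The compounds below may be only part of what the source reports. "The series", "measured", "known", "first", "only" and "open" are said of these compounds alone.

Measured so far:
compound 1, `CCO[C@@H](C1=CC2C(C)=NN(c3ccccc3)C2N=C1)[C@H](OC)[C@@H](O)COC`: 44%
compound 2, `CCO[C@@H](C1=CC2C(c3ccc(O)cc3)=NN(c3ccccc3)C2N=C1)[C@H](O)[C@@H](O)CO`: 40%

Both were tested in a functional assay on THP-1 cells (Homo sapiens) for inhibition, read by ELISA, tested at 10 uM; a lower number here means less inhibition, a higher number more inhibition at the concentration tested (going by the name of the read-out). Compound 1 gives 44% there, and compound 2 gives 40%. Compound 2 has the lower of the two numbers, but its gap to compound 1 lies within the scatter of repeated measurements, so the two cannot be told apart on these figures. Compound 3, `CCO[C@@H](C1=CC2C(C)=NN(c3ccccc3)C2N=C1)[C@H](O)[C@@H](O)CO`, has not yet been measured in this assay. It differs from compound 2 in one place: methyl in place of 4-hydroxyphenyl on a carbon with a double bond to nitrogen. Compound 3 thus shares the core of compound 1 and the chain of compound 2. Among the compounds with values here, no step between two measured compounds is available to size this change; compound 1 and compound 2 differ in two places and still sit within the scatter of each other. The step of a number 2 percentage points higher from compound 2 to compound 3 (within the scatter) is therefore expected to stay within the scatter. Compound 3 is estimated at 42%, between 25% and 60%.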

Compound 3, a percentage reported as inhibition, at one concentration (the size of the read-out at that concentration, not a potency): 44%
Compound 3: the middle estimate sits 2 percentage points below what was measured; the measured number falls inside the stated range.
By their numbers in this assay, from the lowest: compounds 2, 1 and 3 (each within the scatter of the next).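

In this assay, methyl in place of 4-hydroxyphenyl on the carbon with a double bond to nitrogen gives a number 4 percentage points higher from compound 2 to compound 3 (within the scatter), so on these figures a single carbon and a 7-heavy-atom aromatic substituent cannot be told apart at this position. Within the data shown here, the first single-place comparison of the chains, 1,2,3-trihydroxypropyl in place of 2-hydroxy-1,3-dimethoxypropyl, gives no change at the digits printed from compound 1 to compound 3 (within the scatter), and these two chains cannot be told apart either. No measurement at hand offers a cause for either step.

As far as these compounds go, what an amine, a carboxylic acid or a longer alkyl chain on that same carbon would give remains open. These readings also come from a single concentration, so they leave the potency of all three compounds undetermined.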